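Replacing the trimethoxyphenyl group of compound 2

The source may hold more compounds than are shown below. What is called first, only, known or untested is meant among the compounds shown, and "the series" means these compounds.

In a functional assay on A549 cells (Homo sapiens) for cytotoxicity, read by MTT assay, with a stated time of 72 h (a higher number here means a weaker inhibitor, a lower number a stronger inhibitor), compound 1 `O=C(N/N=C/c1cccc(Br)c1)Nc1cc2c(Nc3ccc(F)c(Cl)c3)ncnc2cc1O[C@H]1CCOC1` gives 10700 nM and compound 2 `COc1cc(/C=N/NC(=O)Nc2cc3c(Nc4ccc(F)c(Cl)c4)ncnc3cc2O[C@H]2CCOC2)cc(OC)c1OC` gives 26400 nM. Compound 2 thus holds the higher of the two numbers and is the weaker inhibitor of this pair. Compound 3 `CCN(CC)c1ccc(/C=N/NC(=O)Nc2cc3c(Nc4ccc(F)c(Cl)c4)ncnc3cc2O[C@H]2CCOC2)c(O)c1` keeps the shared core and differs from compound 2 at one place, on a carbon with a double bond to nitrogen, where 4-(diethylamino)-2-hydroxyphenyl stands in place of 3,4,5-trimethoxyphenyl (4-(diethylamino)-2-hydroxyphenyl in place of 3,4,5-trimethoxyphenyl on a carbon with a double bond to nitrogen). Going by the values given here, only one measured step bears on this change. At the same place, 3,4,5-trimethoxyphenyl in place of 3-bromophenyl gave a 2.5-fold higher number from compound 1 to compound 2 (0.39 log units; beyond the scatter), a modest step beyond the scatter. Among the compounds with values here, that step shows that this assay responds to a change at this place, but no measured compound carries a diethylamino or a hydroxy group, so the guide is thin. With compound 2 at the top of the measured numbers, a modest move downward of similar size is expected, though with wide uncertainty. The expected change is a 2.2-fold lower number from compound 2 to compound 3 (0.34 log units; beyond the scatter). Compound 3 is estimated at 12000 nM, within an expected range from 4000 nM to 30000 nM.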

Compound 3, half-maximal inhibitory concentration: 15700 nM
Compound 3: the middle estimate sits 1.3-fold (0.12 log units) below what was measured, within the range that was stated.
By their numbers in this assay, from the lowest: compounds 1, 3 and 2 (each within the scatter of the next, the first and the last beyond it).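

In this assay, the exchange of groups at this place, on a carbon with a double bond to nitrogen, stays within the scatter when compound 3 is set against either earlier compound (first a 1.7-fold lower number from compound 2 to compound 3 (0.23 log units; within the scatter), then a 1.5-fold higher number from compound 1 to compound 3 (0.17 log units; within the scatter)). The earlier compounds shown here showed only that 3-bromophenyl and 3,4,5-trimethoxyphenyl can be told apart here (a 2.5-fold higher number from compound 1 to compound 2 (0.39 log units; beyond the scatter)), whereas 4-(diethylamino)-2-hydroxyphenyl, with one hydrogen-bond donor where 3,4,5-trimethoxyphenyl has none, cannot be separated from either of them, so this single pair of groups gives no clear direction for the position. Nothing available explains these results.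

The compounds shown do not separate the diethylamino group from the hydroxy group, since the two enter together on one phenyl ring and neither appears alone. They also leave open whether a phenyl ring carrying a carboxylic acid or a primary amine at this place, or a longer alkyl chain in place of the ring, would give a number clearly apart from those of compound 1, compound 2 and compound 3.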